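Furan-to-chlorofuran step on a shared core

A few compounds are considered here, and "the series" means these few. Any claim that something is new, unique, unknown or untested is made for them only; others in the source may bear on it.

Compound 1 `Cc1ccc(-c2cc(-c3ccoc3)cc(-c3ccc(Cl)s3)n2)cc1` is the reference point. In an assay on isolated protein for inhibition of DNA topoisomerase 1 (Homo sapiens), with a stated time of 30 min, tested at 100 uM (a lower number here means less inhibition, a higher number more inhibition at the concentration tested (going by the name of the read-out)), compound 1 gives 0%, the lower of the two numbers shown, the gap to the other lying within the scatter. Among the measured compounds shown here, compound 2 `Clc1ccc(-c2cc(-c3ccoc3)cc(-c3ccccn3)n2)s1` gives 3.1% in this assay; the only recorded step, a number 3.1 percentage points higher from compound 1 to compound 2 (within the scatter), concerns pyridin-2-yl in place of 4-methylphenyl on an aromatic carbon and does not leave the scatter. Compound 3 `Cc1ccc(-c2cc(-c3ccc(Cl)o3)cc(-c3ccc(Cl)s3)n2)cc1` is not yet measured in this assay. It differs from compound 1 by 5-chlorofuran-2-yl in place of furan-3-yl on an aromatic carbon. For the measured compounds named here, no measured step touches the furan-3-yl position, so nothing in the data speaks for a change beyond the scatter, and both measured compounds sit near the floor of the read-out. The step of a number 3 percentage points higher from compound 1 to compound 3 (within the scatter) is therefore expected to stay within the scatter. For compound 3 an inhibition of 3% is estimated, with a range from 0% to 15%.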

Compound 3, a percentage reported as inhibition, at one concentration (the size of the read-out at that concentration, not a potency): 14.2%
The estimate for compound 3 lay 11.2 percentage points below the measured number; the measured number falls inside the stated range.
By their numbers in this assay, from the lowest: compounds 1 and 2 (each within the scatter of the next); then compound 3.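

Among the compounds shown here, the position opposite the ring nitrogen is the first place where a change moves the read-out in this assay beyond the scatter: a number 14.2 percentage points higher from compound 1 to compound 3 (beyond the scatter), with 5-chlorofuran-2-yl in place of furan-3-yl. The change of pyridin-2-yl for 4-methylphenyl, a number 3.1 percentage points higher from compound 1 to compound 2 (within the scatter), did not do this, so on the core of compound 1 this position has so far shown a modest response where that one showed none. No available data account for the rise.

The change alters both the furan attachment point and the chlorine at once, and the compounds shown do not separate the two. On these data alone, whether an unsubstituted furan-2-yl, a 5-methylfuran-2-yl, or a group carrying an amine or a carboxylic acid at this position would go further also remains open.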